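A few compounds are considered here, and "the series" means these few. Any claim that something is new, unique, unknown or untested is made for them only; others in the source may bear on it.

Three compounds share one core and differ only in the group attached to it. Compound 1 `CC1(C)C(=O)N(c2ccccc2Cl)c2ncccc21` carries a chloro group on its ring, compound 2 `CC1(C)C(=O)N(c2cccc(C(F)(F)F)c2)c2ncccc21` a trifluoromethyl group on its ring, and compound 3 `CC1(C)C(=O)N(Cc2ccccc2)c2ncccc21` a benzyl group. All three were tested in a functional assay on the whole organism (Pleural cavity) for inhibition, with Rattus norvegicus as the target, at a dose of 25 mg/kg; a lower number here means less inhibition, a higher number more inhibition at the dose given (going by the name of the read-out). In this assay compound 1 gives 3%, compound 2 gives 10% and compound 3 gives 12%. Compound 2 thus sits among three low numbers; its value lies within the usual scatter of both compound 3 and compound 1, so none of the three can be set apart from the others.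

Compound 4 `CC1(C)C(=O)N(c2cccc(Cl)c2)c2ncccc21` has not yet been measured. It differs from compound 2 in one place: chloro in place of trifluoromethyl on an aromatic carbon. Among the compounds with values here, no pair of measured compounds differing in one place is available, so the effect of this change cannot be read directly from the data. Compound 4 is expected to stay low because compound 1 with its own chloro group gives 3% in this assay. The step of a number 2 percentage points lower from compound 2 to compound 4 (within the scatter) is expected to be no larger than the scatter, in no particular direction. For compound 4 the estimate in this assay is 8%, with a range from 0% to 20%.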

Compound 4, a percentage reported as inhibition, in the whole organism at one dose (the size of the read-out at that dose, not a potency): 49%
For compound 4 the middle estimate is 41 percentage points below the measured one; measured number outside the range, above it.
By their numbers in this assay, from the lowest: compounds 1, 2 and 3 (each within the scatter of the next); then compound 4.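

In this assay, replacing trifluoromethyl with chloro on this aromatic carbon, meta to a large group, gives a number 39 percentage points higher from compound 2 to compound 4 (beyond the scatter), the only step shown between compounds that differ in one place, which means that a single substituent at this position can strongly change the read-out at this dose. The presence of a chloro group does not settle the outcome on its own: compound 1, with its chloro group at a different place on the ring, gives 3%, whereas compound 4 gives 49%. Nothing measured here accounts for the size of this step.

On these data alone, it remains open whether other groups at this same position, such as methyl, methoxy, an amine or a carboxylic acid, would keep the inhibition seen with chloro or lose it. A single pair also cannot show whether the same replacement would produce a similar step on another core, and a reading at one dose gives the size of the effect at that dose, not a potency.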